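The compounds below may be only part of what the source reports. "The series", "measured", "known", "first", "only" and "open" are said of these compounds alone.

Measured compounds:
Compound 1, `Cc1c(Cl)cccc1-c1cccc(COc2ccc([C@H](CC(=O)O)c3nccn3C)cc2)c1`; in an assay on CHO cells for agonist activity at Free fatty acid receptor 1 (Homo sapiens), read by luminescence, with a stated time of 20 s, in the presence of a further agent that is not named here (on this read-out higher numbers stand for an effect only at larger amounts of compound and lower numbers for an effect already at smaller amounts), compound 1 gives 22000 nM.
Compound 2, `Cc1ccc(F)cc1-c1cccc(COc2ccc([C@H](CC(=O)O)c3nccn3C)cc2)c1`; in this assay compound 2 gives 42000 nM.

Among the measured compounds shown here, compound 2 stands at the higher of the two numbers, with compound 1 the only neighbour; the step between them, a 1.9-fold higher number from compound 1 to compound 2 (0.28 log units; within the scatter), lies within the scatter, so the two are not distinguished. Compound 3, `Cc1cc(F)ccc1-c1cccc(COc2ccc([C@H](CC(=O)O)c3nccn3C)cc2)c1`, differs from compound 2 by 4-fluoro-2-methylphenyl in place of 5-fluoro-2-methylphenyl on an aromatic carbon. For the measured compounds named here, the single measured step, from compound 1 to compound 2, exchanged both the halogen and its position at once, and was within the scatter; no measured step moves only the fluorine on this ring, so nothing bears directly on the change to compound 3. On that basis compound 3 is expected to show no step beyond the scatter, a 1.2-fold lower number from compound 2 to compound 3 (0.08 log units; within the scatter). Compound 3 is estimated at 35000 nM, with a range from 12000 nM to 100000 nM.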

Compound 3, half-maximal effective concentration: 21000 nM
For compound 3 the middle estimate is 1.7-fold (0.22 log units) above the measured one, and the stated range covers the measured number.
By their numbers in this assay, from the lowest: compounds 3, 1 and 2 (each within the scatter of the next).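

Moving the fluorine alone, with 4-fluoro-2-methylphenyl in place of 5-fluoro-2-methylphenyl, gives in this assay a 2.0-fold lower number from compound 2 to compound 3 (0.30 log units; within the scatter) and so leaves the two compounds undistinguished, which is the first direct reading of the fluorine's place on this ring. Exchanging the chlorine-bearing ring for 4-fluoro-2-methylphenyl gives a 1.0-fold lower number from compound 1 to compound 3 (0.02 log units; within the scatter) and likewise separates nothing, so neither the halogen nor its place on this ring has yet produced a step beyond the scatter. No evidence is available that bears on these numbers.

From the compounds shown here alone, it remains open whether a methoxy group or a nitrile on this ring, in place of the halogen, would give a step beyond the scatter. How the numbers respond to changes elsewhere in the core is also untested by these compounds, which all share it.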